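A few compounds are considered here, and "the series" means these few. Any claim that something is new, unique, unknown or untested is made for them only; others in the source may bear on it.

Compound 1 `O=C1C=CC2(C=C1)OCC(=O)N2S(=O)(=O)c1ccccc1`: > 10000 nM
Compound 2 `COc1ccc(S(=O)(=O)N2C(=O)COC23C=CC(=O)C=C3)cc1`: > 10000 nM
Compound 3 `O=C1C=CC2(C=C1)OCC(=O)N2S(=O)(=O)c1ccc(OC(F)(F)F)cc1`: > 10000 nM

All three compounds were tested in a functional assay on MDA-MB-231 cells (Homo sapiens) for inhibition, read by sulforhodamine B assay, with a stated time of 74 h (a higher number here means a weaker inhibitor, a lower number a stronger inhibitor), and each entry is a limit of the assay, not a number. Compound 3 gives > 10000 nM as such a limit, so its place in the series cannot be fixed any more closely. The same holds for the other two compounds, and the whole record so far is the limit of > 10000 nM in this assay, at which 3 of the 3 values shown sit, with nothing further to read.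

Compound 4 `O=C1C=CC2(C=C1)OCC(=O)N2S(=O)(=O)c1ccc(C(F)(F)F)cc1` has not yet been measured. Its difference from compound 3 is trifluoromethyl in place of trifluoromethoxy on an aromatic carbon, para to a large group.

Among the measured compounds shown here, three measured steps bear on this change, each altering the group at that place. They are a step that the two limits leave unreadable from compound 1 to compound 2, a step that the two limits leave unreadable from compound 1 to compound 3 and a step that the two limits leave unreadable from compound 2 to compound 3, and none of them has a readable size. With no number yet in the series, no step beyond the scatter is expected in this assay, and compound 4 is expected to report a limit too, though this rests on limits alone. The estimated step, a number no higher from compound 3 to compound 4 (the limit leaves the size open), has no favoured direction. For compound 4 the estimated value is 10000 nM, with an expected range from 3000 nM to 20000 nM.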

Compound 4, half-maximal inhibitory concentration: 2100 nM
For compound 4 the middle estimate is 4.8-fold (0.68 log units) above the measured one, outside the stated range (below it).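

In this assay, among the compounds shown here, the group on an aromatic carbon, para to a large group, proves able to shift the result, as trifluoromethyl brings the first readable value of the series where hydrogen, methoxy and trifluoromethoxy did not: the change gives an at least 4.7-fold lower number from compound 3 to compound 4 (0.67 log units; beyond the scatter), an at least 4.7-fold lower number from compound 2 to compound 4 (0.67 log units; beyond the scatter) and an at least 4.7-fold lower number from compound 1 to compound 4 (0.67 log units; beyond the scatter). The earlier steps shown here among compounds 1, 2 and 3 could not be read, so they showed nothing about this place, whereas the new steps show that trifluoromethyl and trifluoromethoxy are not interchangeable here, though they differ only by the oxygen counted among the atoms that leave. Compound 4 alone comes off the limit of the assay, and the other three compounds stay at it: the limit of > 10000 nM in this assay, at which 3 of the 4 values shown sit.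

Going by these compounds, the true size of each new step stays open, since the entries for compounds 1, 2 and 3 are limits and not numbers. The compounds shown also do not tell whether another group at this place, such as a nitrile, an amine or a carboxylic acid, would give a lower or a higher number than trifluoromethyl does.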